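The source may hold more compounds than are shown below. What is called first, only, known or untested is meant among the compounds shown, and "the series" means these compounds.

Compound 3 `COc1cc2ncnc(-n3nc(-c4ccccn4)nc3N)c2cc1OCc1ccccc1` holds the lowest of the two numbers measured in an assay on MCF7 cells for inhibition of Serine-protein kinase ATM (Homo sapiens), read by immunofluorescence, with a stated time of 1 h; a higher number here means a weaker inhibitor, a lower number a stronger inhibitor: in this assay compound 3 gives 8600 nM. Going by the values given here, compound 2 `COc1cc2ncnc(-n3nc(-c4ccccn4)nc3N)c2cc1[N+](=O)[O-]` gives 31100 nM in this assay, and the step of a 3.6-fold lower number from compound 2 to compound 3 (0.56 log units; beyond the scatter) is the only measured step in the set. Among the compounds with values here, compound 1 `Nc1nc(-c2ccccc2)nn1-c1ncnc2cc(Cl)ccc12` gives only a limit in this assay, > 40000 nM, and the limit of > 40000 nM in this assay, at which 1 of the 3 values shown sits, is the sole evidence attached to it.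

Compound 4 `COCCOc1cc2c(-n3nc(-c4ccccn4)nc3N)ncnc2cc1OC` differs from compound 3 by methoxymethyl in place of phenyl on a saturated chain carbon bound to an oxygen on an aromatic ring. Within the data shown here, no measured step covers this change: the single measured step, a 3.6-fold lower number from compound 2 to compound 3 (0.56 log units; beyond the scatter), exchanges nitro for benzyloxy on an aromatic carbon and leaves the benzyl part itself untouched, so the loss of phenyl for methoxymethyl has no precedent here. The estimate for compound 4 therefore rests on compound 3 alone and carries a wide range. The step of a 1.4-fold higher number from compound 3 to compound 4 (0.14 log units; within the scatter) is expected to be small, without a clear direction beyond the scatter. Compound 4 is expected to give about 12000 nM in this assay, between 3500 nM and 40000 nM.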

Compound 4, half-maximal inhibitory concentration: 1200 nM
For compound 4 the middle estimate is 10-fold (1.00 log units) above the measured one; measured number below the stated range.
By their numbers in this assay, from the lowest: compound 4; then compound 3; then compound 2. At a limit, above all of these: compound 1.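

Replacing benzyloxy with 2-methoxyethoxy gives a 7.2-fold lower number from compound 3 to compound 4 (0.86 log units; beyond the scatter) in this assay, so a phenyl ring is not required at this position, and a chain ending in methoxymethyl, with no ring, is the better of the two here. Set against nitro on the same aromatic carbon, 2-methoxyethoxy gives a 26-fold lower number from compound 2 to compound 4 (1.41 log units; beyond the scatter), a larger step than a 3.6-fold lower number from compound 2 to compound 3 (0.56 log units; beyond the scatter). Nothing to hand bears on the reason for this gain.

As far as these compounds go, whether the gain comes from the oxygen of methoxymethyl or simply from the loss of phenyl remains open, and an all-carbon chain such as propoxy would separate the two. From the compounds shown here alone, how far the position tolerates further change also remains open, for instance a longer chain ending in an amine or a carboxylic acid.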